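From chloro to bromo: what size of step to expect

A few compounds are considered here, and "the series" means these few. Any claim that something is new, unique, unknown or untested is made for them only; others in the source may bear on it.

Compound 1 `COc1ccc(C2CC(c3ccc4c(c3)OCCO4)=NN2c2ccccc2)cc1OC`: 2160 nM
Compound 2 `Clc1ccc(C2CC(c3ccc4c(c3)OCCO4)=NN2c2ccccc2)cc1`: 38600 nM

In a functional assay on WM 266-4 cells (Homo sapiens) for antiproliferative activity, read by MTT assay, with a stated time of 24 h (on this read-out higher numbers stand for weaker inhibition of growth and lower numbers for stronger inhibition of growth), compound 2 holds the higher of the two numbers, at 38600 nM, so it inhibits growth less strongly than compound 1. Compound 3 `Brc1ccc(C2CC(c3ccc4c(c3)OCCO4)=NN2c2ccccc2)cc1` has bromo in place of chloro on an aromatic carbon. For the measured compounds named here, only one measured step bears on this change, and only loosely. That step, an 18-fold higher number from compound 1 to compound 2 (1.25 log units; beyond the scatter), is large, but it puts 4-chlorophenyl in place of 3,4-dimethoxyphenyl on a saturated ring carbon. Going by the values given here, no measured step shows one halogen exchanged for another, so the size of that step does not carry over. No step beyond the scatter is therefore expected. The estimated step is a 1.4-fold lower number from compound 2 to compound 3 (0.16 log units; within the scatter). Compound 3 is expected to give 27000 nM. Its estimated range runs from 9000 nM to 65000 nM.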

Compound 3, concentration for 50% growth inhibition: 3010 nM
For compound 3 the middle estimate is 9.0-fold (0.95 log units) above the measured one; measured number outside the range, below it.
By their numbers in this assay, from the lowest: compounds 1 and 3 (each within the scatter of the next); then compound 2.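

In this assay the exchange of a single atom proves far from neutral: going from 4-chlorophenyl to 4-bromophenyl, on an aromatic carbon para to a large group, gives a 13-fold lower number from compound 2 to compound 3 (1.11 log units; beyond the scatter) and so restores strong inhibition of growth. The comparison with the 3,4-dimethoxyphenyl group shows a 1.4-fold higher number from compound 1 to compound 3 (0.14 log units; within the scatter) and places the two groups level, so the large step seen earlier from compound 1 to compound 2 does not hold for every halogen at this position. Nothing on hand explains why chloro and bromo differ so sharply here.

The compounds shown leave open whether fluoro, iodo or an amine at the same carbon would track compound 2 or compound 3. They also leave open whether compound 2 is an isolated low point or part of a wider trend among such groups.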